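Trimming the pyrazole substituent on a shared kinase-inhibitor core

The compounds below may be only part of what the source reports. "The series", "measured", "known", "first", "only" and "open" are said of these compounds alone.

Compound 3 `Cc1c(Nc2nc(N)c3c(C#N)c(N4CCC[C@H]4C)n(C)c3n2)cnn1C1COC1` gives 37 nM in an assay on isolated protein for inhibition of Leucine-rich repeat serine/threonine-protein kinase 2 variant G2019S (Homo sapiens), read by TR-FRET and LanthaScreen, with stated times of 50 min and 30 min, in the presence of a further agent that is not named here (on this read-out higher numbers stand for weaker inhibition and lower numbers for stronger inhibition), the highest of the three numbers in hand. Compound 1 `Cc1nn(C2COC2)cc1Nc1nc(N)c2c(C#N)c(N3CCC[C@H]3C)n(C)c2n1` lies nearest, the step being a 1.5-fold higher number from compound 1 to compound 3 (0.17 log units; within the scatter) and within the scatter, while compound 1 gives 25 nM. Compound 2 `C[C@@H]1CCCN1c1c(C#N)c2c(N)ncnc2n1C` lies furthest, beyond the scatter, and in this assay compound 2 gives 11 nM. Compound 4 `C[C@@H]1CCCN1c1c(C#N)c2c(N)nc(Nc3cnn(C)c3)nc2n1C` differs from compound 3 by 1-methyl-1H-pyrazol-4-yl in place of 5-methyl-1-(oxetan-3-yl)-1H-pyrazol-4-yl on a nitrogen on an aromatic ring. For the measured compounds named here, the only measured step that touches this pyrazole is a 1.5-fold higher number from compound 1 to compound 3 (0.17 log units; within the scatter), which stayed within the scatter; no measured step removes the oxetane. The change is therefore expected to leave this assay roughly unchanged, the estimated step being a 1.1-fold lower number from compound 3 to compound 4 (0.02 log units; within the scatter). Compound 4 is expected to give 35 nM, estimated between 12 nM and 100 nM.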

Compound 4, half-maximal inhibitory concentration: 5 nM
Beside the measured number, compound 4's estimate is 7.0-fold (0.85 log units) above it; measured number below the stated range.
By their numbers in this assay, from the lowest: compound 4; then compound 2; then compounds 1 and 3 (each within the scatter of the next).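

Here the pyrazole change is not silent: this assay records a 7.4-fold lower number from compound 3 to compound 4 (0.87 log units; beyond the scatter) and, starting from the 3-methyl isomer, a 5.0-fold lower number from compound 1 to compound 4 (0.70 log units; beyond the scatter) for the same entering 1-methyl-1H-pyrazol-4-yl group. Putting the (1-methyl-1H-pyrazol-4-yl)amino group in place of hydrogen on an aromatic carbon also gives a 2.2-fold lower number from compound 2 to compound 4 (0.34 log units; beyond the scatter) in this series, so on the shared core this group lowers the number. The compounds shown leave open whether losing the oxetan-3-yl or the ring methyl carries the step, and how an ethyl or 2-methoxyethyl on that pyrazole nitrogen would read. No evidence in hand gives a cause for these steps.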